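The source may report more compounds than this note shows. Statements on the series, on what has been measured and on what is new or still open speak of the compounds shown alone.

Working notes on the sulfonamide series.

Compound 3 `O=C1NCCN1c1ccc(S(=O)(=O)Nc2ccc(Br)cc2)cc1` shows the lowest number of the three measured compounds in a functional assay on HT-29 cells (Homo sapiens) for antiproliferative activity, read by sulforhodamine B assay, with a stated time of 48 h (a lower number here means a stronger inhibitor, a higher number a weaker inhibitor), giving 300 nM. Compound 1 `O=C1NCCN1c1ccc(S(=O)(=O)Nc2ccc(OC(F)F)cc2)cc1` gives 650 nM in this assay, and compound 2 `CCCCOc1ccc(NS(=O)(=O)c2ccc(N3CCNC3=O)cc2)cc1` gives 630 nM. The move from compound 1 to compound 2 is a 1.0-fold lower number from compound 1 to compound 2 (0.01 log units; within the scatter), so those two cannot be ordered. Replacing the oxygen-linked groups with bromo gives a 2.2-fold lower number from compound 1 to compound 3 (0.34 log units; beyond the scatter) and a 2.1-fold lower number from compound 2 to compound 3 (0.32 log units; beyond the scatter), both modest but beyond the scatter.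

Compound 4 `CCc1cccc(NS(=O)(=O)c2ccc(N3CCNC3=O)cc2)c1` differs from compound 3 as follows: 3-ethylphenyl in place of 4-bromophenyl on a sulfonamide nitrogen. For the measured compounds named here, no measured step puts an ethyl-bearing ring on the sulfonamide nitrogen, so the closest guidance is that the two measured departures from bromo, in compound 1 and compound 2, each sit about two steps of scatter higher. A similar modest rise in this assay is therefore expected for compound 4, that is a step of a 1.8-fold higher number from compound 3 to compound 4 (0.26 log units; within the scatter). The estimate for compound 4 in this assay is 550 nM, with an expected range from 250 nM to 1300 nM.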

Compound 4, half-maximal inhibitory concentration: 110 nM
Compound 4: the middle estimate sits 5.0-fold (0.70 log units) above what was measured; measured number below the stated range.
By their numbers in this assay, from the lowest: compound 4; then compound 3; then compounds 2 and 1 (each within the scatter of the next).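

The change to 3-ethylphenyl in place of 4-bromophenyl on the sulfonamide nitrogen gives a 2.7-fold lower number from compound 3 to compound 4 (0.44 log units; beyond the scatter) in this assay, so bromo is not needed for the lowest number seen so far at this position, and compound 4 goes against the earlier picture in which departures from bromo only raised the number. The group and its place on the ring differ together in this step, so the size of the step cannot be assigned to either one alone. Nothing available explains the drop.

The compounds shown do not separate the effect of the ethyl group from that of its place on the ring. On these data alone, how a longer chain such as propyl, an amine or a carboxylic acid on this ring would compare also stays open.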